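A few compounds are considered here, and "the series" means these few. Any claim that something is new, unique, unknown or untested is made for them only; others in the source may bear on it.

Compound 1, `O=C(O)[C@@H]1NC[C@H](O)[C@H](O)[C@H]1O`: in an assay for inhibition of alpha-N-acetylgalactosaminidase (Gallus gallus), tested at 1000 uM (a higher number here means more inhibition at the concentration tested (going by the name of the read-out), a lower number less inhibition), compound 1 gives 4.4%.
Compound 2, `O=C(O)[C@@H]1NC[C@H](O)[C@@H](O)[C@H]1O`: in this assay compound 2 gives 4%.
Compound 3, `O=C(O)[C@H]1NC[C@@H](O)[C@@H](O)[C@@H]1O`: in this assay compound 3 gives 3.8%.

The three compounds are stereoisomers of one another: the fact that compounds 1 and 2 differ only in the configuration as drawn, (the fact that compounds 1 and 3 differ only in the configuration as drawn), and (the fact that compounds 2 and 3 differ only in the configuration as drawn). None of the changes in configuration moved the read-out: a number 0.4 percentage points lower from compound 1 to compound 2 (within the scatter), a number 0.6 percentage points lower from compound 1 to compound 3 (within the scatter), and a number 0.2 percentage points lower from compound 2 to compound 3 (within the scatter). On the numbers shown, compound 3 stands lowest of the three, but its gaps to compound 2 and to compound 1 lie within the scatter, so the three cannot be told apart in this assay.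

Compound 4, `O=C(O)[C@H]1NC[C@@H](O)[C@H](O)[C@H]1O`, is a further stereoisomer. the two compounds have the same atoms and bonds and differ only in configuration as drawn: 2 of 4 stereo elements differ; a stereocentre at a saturated ring carbon is drawn R in compound 3 and S in compound 4; a stereocentre at a saturated ring carbon is drawn R in compound 3 and S in compound 4 All three measured steps bear on this change, since each of them is also a pure change of configuration, and each stayed within the scatter. The step from compound 3 to compound 4 in this assay is therefore expected to be a number 0.2 percentage points higher from compound 3 to compound 4 (within the scatter), that is, nothing beyond the scatter. Compound 4 is estimated to give 4% in this assay, expected to fall between -4% and 12%.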

Compound 4, a percentage reported as inhibition, at one concentration (the size of the read-out at that concentration, not a potency): 4.2%
The estimate for compound 4 lay 0.2 percentage points below the measured number; the range from low to high includes it.
By their numbers in this assay, from the lowest: compounds 3, 2, 4 and 1 (each within the scatter of the next).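

Compound 4 brings a further arrangement of the stereocentres into the comparison, and every step that reaches it stays within the scatter (a number 0.4 percentage points higher from compound 3 to compound 4 (within the scatter)) (a number 0.2 percentage points higher from compound 2 to compound 4 (within the scatter)) (a number 0.2 percentage points lower from compound 1 to compound 4 (within the scatter)). These steps change two or three stereo elements at once, so in this assay the read-out does not separate these combinations of inverted stereocentres any more than it separated the earlier ones. Compound 4 therefore cannot be told apart from compound 1, compound 2 or compound 3, and the comparison with compound 3 rests on configuration alone: the fact that compounds 3 and 4 differ only in the configuration as drawn.

From the compounds shown here alone, it remains open whether a change other than configuration would shift the read-out, such as a methyl ester or an amide in place of the carboxylic acid, or a longer chain on the shared core. Going by these compounds, it is also open whether these four stereoisomers would separate against another enzyme.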